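A few compounds are considered here, and "the series" means these few. Any claim that something is new, unique, unknown or untested is made for them only; others in the source may bear on it.

Compound 1 `CC(C)COc1ccc(-c2cn3c(=O)n(-c4ccccc4)nc3c(N)n2)cc1` — "not determined" (no result reported).
Compound 2 `CCCOc1ccc(-c2cn3c(=O)n(-c4ccccc4)nc3c(N)n2)cc1` — a limit of the assay, > 30000 nM.
Compound 3 `C=CCOc1ccc(-c2cn3c(=O)n(-c4ccccc4)nc3c(N)n2)cc1` — "not determined" (no result reported).

In a functional assay on cells for antagonist activity at adenosine receptor A2b (Homo sapiens), read by cAMP accumulation, with a stated time of 10 min (a higher number here means a weaker inhibitor, a lower number a stronger inhibitor), compound 3 holds no number of its own, its entry reading "not determined" (no result reported). Compound 1 likewise carries no number in this assay. Among the measured compounds shown here, compound 2 sits at a limit of this assay, (the limit of > 30000 nM in this assay, at which 1 of the 3 values shown sits), and so no step between measured compounds is available. Compound 4 `CC(C)Oc1ccc(-c2cn3c(=O)n(-c4ccccc4)nc3c(N)n2)cc1` differs from compound 3 by isopropyl in place of allyl on an oxygen on an aromatic ring. Without a measured step the size and direction of this change cannot be read from the data. With compound 2 at the limit of > 30000 nM in this assay, at which 1 of the 3 values shown sits, compound 4 is expected to give 30000 nM in this assay, somewhere between 5000 nM and 100000 nM.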

Compound 4, half-maximal inhibitory concentration: > 30000 nM
Compound 4 was reported as a limit; the forecaster's own chance of this, stated with the estimate: 70%; the middle value sits exactly at the limit.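

No step can be read between compound 2 and compound 4, as both stand at a limit of this assay: the limit of > 30000 nM in this assay, at which 2 of the 4 values shown sit.

The compounds shown leave open how propyl and isopropyl on that oxygen compare, as none of them carries a single number in this assay.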